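The source may report more compounds than this note shows. Statements on the series, on what has been measured and on what is new or still open speak of the compounds shown alone.

Notes on the series. Compound 1 `O=C(CSc1nc(Nc2ccccc2)c2ccccc2n1)Nc1ccccc1Br` is the reference point; in a functional assay on NCI-H1975 cells (Homo sapiens) for inhibition, read by MTT assay, with a stated time of 72 h (on this read-out higher numbers stand for weaker inhibition and lower numbers for stronger inhibition), compound 1 gives 10300 nM. Within the data shown here, compound 2 `COc1cccc(NC(=O)CSc2nc(Nc3ccccc3)c3ccccc3n2)c1` carries 3-methoxyphenyl in place of 2-bromophenyl on an amide-type nitrogen, and compound 2 gives 19400 nM; the step of a 1.9-fold higher number from compound 1 to compound 2 (0.27 log units; within the scatter) is the only single-change step measured so far. Compound 3 `C=CC(=O)Nc1cccc(NC(=O)CSc2nc(Nc3ccccc3Br)c3ccccc3n2)c1` gives 19300 nM. On the three numbers in hand compound 3 sits within the scatter of both others: the gap to compound 2 is nil and the gap to compound 1 is also inside the scatter, so the three compounds cannot be ranked on this assay.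

Compound 4 `C=CC(=O)Nc1cccc(NC(=O)CSc2nc(Nc3ccc(Cl)cc3Cl)c3ccccc3n2)c1` differs from compound 3 by 2,4-dichlorophenyl in place of 2-bromophenyl on a nitrogen on an aromatic ring. Among the measured compounds shown here, no measured step touches this nitrogen; the one step available, from compound 1 to compound 2, concerns a different nitrogen and was itself inside the scatter. Nothing in the data therefore points to a change beyond the scatter in this assay. The step from compound 3 to compound 4 is expected to be a 1.0-fold higher number from compound 3 to compound 4 (0.02 log units; within the scatter). Compound 4 is accordingly estimated at 20000 nM, with a range from 8000 nM to 50000 nM.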

Compound 4, half-maximal inhibitory concentration: 5990 nM
The estimate for compound 4 lay 3.3-fold (0.52 log units) above the measured number; measured number below the stated range.
By their numbers in this assay, from the lowest: compounds 4, 1, 3 and 2 (each within the scatter of the next, the first and the last beyond it).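

Among these compounds, the aryl group on the nitrogen on an aromatic ring is the first place where a single change moves the number in this assay beyond the scatter (a 3.2-fold lower number from compound 3 to compound 4 (0.51 log units; beyond the scatter)), with 2,4-dichlorophenyl in place of 2-bromophenyl. Among the compounds shown here, the only earlier single-change step (a 1.9-fold higher number from compound 1 to compound 2 (0.27 log units; within the scatter)) concerned an amide-type nitrogen and stayed within the scatter, so it gave no sign that the series could respond at all, whereas this position does respond, though modestly and on the strength of a single pair. No measurement in hand bears on what lies behind this shift.

The swap removes bromine and brings in two chlorines in one step, so the compounds shown cannot separate the loss of the one from the gain of the other, and a phenyl carrying a single chlorine would be needed to divide the effect. From the compounds shown here alone, it also remains open whether the gain extends to other groups at this nitrogen, such as a pyridyl ring or a phenyl carrying an amine, and whether it holds with other groups on the amide-type nitrogen.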